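From a butylamino chain to a methylpiperazine

This account rests on a few compounds, and the source may have more. Where it says the series, first, only, none or still open, it means among the compounds named here.

Compound 1 (`CCCCNCCCCOc1c(O)cc(O)c2c(=O)cc(-c3ccccc3)oc12`) offers no starting number: in a functional assay on A549 cells (Homo sapiens) for cytotoxicity, read by MTT assay, with a stated time of 48 h (on this read-out lower numbers stand for stronger inhibition and higher numbers for weaker inhibition), compound 1 is recorded as "not determined" (no result reported). The step to compound 4 (`CN1CCN(CCCOc2c(O)cc(O)c3c(=O)cc(-c4ccccc4)oc23)CC1`) is 4-methylpiperazin-1-yl in place of (butylamino)methyl on a saturated chain carbon, three bonds along the chain from an oxygen on an aromatic ring, which puts 4-methylpiperazin-1-yl in place of (butylamino)methyl, three bonds along the chain from an oxygen on an aromatic ring.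

For the measured compounds named here, two relatives give the only guidance. Compound 2 (`COc1c(OCCCCNCc2ccccc2)cc(O)c2c(=O)cc(-c3ccccc3)oc12`), with a benzylamino chain, gives 4590 nM. Compound 3 (`COc1c(OCc2ncc(C)o2)cc(O)c2c(=O)cc(-c3ccccc3)oc12`) gives > 100000 nM, which is a limit of the assay and not a number. Going by the values given here, the single measured step, an at least 21-fold higher number from compound 2 to compound 3 (1.33 log units; beyond the scatter), is large, and it replaces the 3-(benzylamino)propyl group with 5-methyl-1,3-oxazol-2-yl.

Compound 4 keeps a nitrogen-bearing chain, so it resembles compound 2 more than compound 3 at this spot. With no number for compound 1, no size or direction can be expected for the step itself in this assay. A value moderately weaker than that of compound 2 at 4590 nM seems most likely. For compound 4 the expected value is 12000 nM, with an estimated range from 3000 nM to 50000 nM.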

Compound 4, half-maximal inhibitory concentration: > 100000 nM
Compound 4 gave a limit, no number; the forecaster's own chance of this, stated with the estimate: 15%; middle value at least 8.3-fold (0.92 log units) from the limit.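

For the compounds shown here, compound 1 has no reported result in this assay, so no step from compound 1 to compound 4 can be read. Compound 4 gives a limit, not a number: the limit of > 100000 nM in this assay, at which 2 of the 4 values shown sit. The compounds shown leave open how 4-methylpiperazin-1-yl compares with (butylamino)methyl on this chain.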